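This account rests on a few compounds, and the source may have more. Where it says the series, first, only, none or still open, it means among the compounds named here.

Measured in an ADME assay on HEK293 cells (Homo sapiens) for cytotoxicity, read by fluorescence and resazurin assay, with a stated time of 20 h (a higher number here means that more compound is tolerated, a lower number that less compound is tolerated), so far:

Compound 1 `CC(C)CCc1sc(NC(=O)c2cc(NC(=O)c3cc(NC(=N)c4cccc(F)c4)cn3C)cn2C)nc1C(=O)NCCCN(C)C` — 18 ug/mL
Compound 2 `CN(C)CCCNC(=O)c1cc(NC(=O)c2cc(NC(=O)c3cc(NC(=N)N)cn3C)cn2C)cn1C` — "not determined" (no result reported)
Compound 3 `CC(C)CCc1sc(NC(=O)c2cc(NC(=O)c3cc(NC(=N)c4ccc(F)cc4)cn3C)cn2C)nc1C(=O)NCCCN(C)C` — 18 ug/mL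

Compound 3 therefore stands level with compound 1 at the digits shown, and compound 2 gives no number to compare with. Among the compounds with values here, the only measured step with a single change is no change at the digits printed from compound 1 to compound 3 (within the scatter), a swap of one fluorophenyl group for another at the same place, and it left the reading where it was.

Compound 4 `CC(C)CCc1sc(NC(=O)c2cc(NC(=O)c3cc(NC(=N)c4cccc(Cl)c4)cn3C)cn2C)nc1C(=O)NCCCN(C)C` follows from compound 3 by a change of the same kind at the same place: 3-chlorophenyl in place of 4-fluorophenyl on a carbon with a double bond to nitrogen. Within the data shown here, the one step that bears on it, from compound 1 to compound 3, was flat, so a change of substituent on this ring has so far not moved the reading. The step of a 1.1-fold lower number from compound 3 to compound 4 (0.05 log units; within the scatter) is expected to stay within the scatter. Compound 4 is estimated at 16 ug/mL, with a likely range from 8 ug/mL to 32 ug/mL.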

Compound 4, half-maximal cytotoxic concentration: 9.2 ug/mL
For compound 4 the middle estimate is 1.7-fold (0.24 log units) above the measured one, and the stated range covers the measured number.
By their numbers in this assay, from the lowest: compounds 4, 1 and 3 (each within the scatter of the next).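

In this assay, chloro in place of fluoro on an aromatic carbon, with the ring position kept, gives a 2.0-fold lower number from compound 1 to compound 4 (0.29 log units; within the scatter). Moving to 3-chlorophenyl in place of 4-fluorophenyl gives a 2.0-fold lower number from compound 3 to compound 4 (0.29 log units; within the scatter), so these are larger steps than the earlier swap between fluorophenyl groups, yet both stay within the scatter and compounds 1, 3 and 4 cannot be told apart at this place. No measurement shown offers an explanation for the size of these steps.

From the compounds shown here alone, all three groups at this place are phenyl rings bearing a halogen, so it remains open how an unsubstituted phenyl, a methoxyphenyl or an aminophenyl would read. Going by these compounds, it also remains open whether a carboxylic acid in place of the dimethylaminopropyl chain would move the reading beyond the scatter.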